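This account rests on a few compounds, and the source may have more. Where it says the series, first, only, none or still open, it means among the compounds named here.

Measured in a functional assay on HL-60 cells (Homo sapiens) for inhibition, read by MTT assay, with a stated time of 72 h; on this read-out lower numbers stand for stronger inhibition and higher numbers for weaker inhibition:
Compound 1 `Cc1nc(-c2ccccc2)c(C(=O)N2CCN(c3cccc(C)c3C)CC2)o1`: 35 nM
Compound 2 `Cc1ccc(C)c(N2CCN(C(=O)c3oc(C)nc3-c3ccccc3)CC2)c1`: 31.3 nM
Compound 3 `Cc1nc(-c2ccccc2)c(C(=O)N2CCN(c3ccccc3C(F)(F)F)CC2)o1`: 120 nM

Compound 3 has the highest number of the three, beyond the scatter from both others. Compound 4 `Cc1nc(-c2ccccc2)c(C(=O)N2CCN(c3ccccc3F)CC2)o1` is unmeasured and differs from compound 3 as follows: fluoro in place of trifluoromethyl on an aromatic carbon. Going by the values given here, no measured step makes this exact exchange. The nearest evidence comes from two changes of the aryl group, a 3.4-fold higher number from compound 1 to compound 3 (0.54 log units; beyond the scatter) and a 3.8-fold higher number from compound 2 to compound 3 (0.58 log units; beyond the scatter), both modest. A step no larger than these is therefore expected in this assay. The data fix no direction, so only a small move toward lower numbers is assumed. The expected step is a 1.3-fold lower number from compound 3 to compound 4 (0.12 log units; within the scatter). For compound 4 the estimated value is 90 nM, with a range from 30 nM to 270 nM.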

Compound 4, half-maximal inhibitory concentration: 147 nM
The estimate for compound 4 lay 1.6-fold (0.21 log units) below the measured number; low and high end bracket the measured number.
By their numbers in this assay, from the lowest: compounds 2 and 1 (each within the scatter of the next); then compounds 3 and 4 (each within the scatter of the next).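

In this assay the exchange of trifluoromethyl for fluoro, on an aromatic carbon ortho to a large group, gives a step within the scatter (a 1.2-fold higher number from compound 3 to compound 4 (0.09 log units; within the scatter)), so these two groups do not separate at this place, although one has four heavy atoms and the other one. The 2-fluorophenyl group stays apart from both dimethylphenyl groups (a 4.7-fold higher number from compound 2 to compound 4 (0.67 log units; beyond the scatter); a 4.2-fold higher number from compound 1 to compound 4 (0.62 log units; beyond the scatter)). Nothing available explains these differences. Still open, on these data alone, is whether a lone methyl or a methoxy group at this place would give numbers nearer those of compound 1 and compound 2 or nearer those of compound 3 and compound 4.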